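The source may report more compounds than this note shows. Statements on the series, on what has been measured and on what is new or still open speak of the compounds shown alone.

Compound 1, `Cc1n[nH]cc1-c1cccc2c1CCC2c1ncc[nH]1`, in a functional assay on CHO cells for agonist activity at Alpha-1D adrenergic receptor (Homo sapiens), read by FLIPR and calcium flux (a lower number here means that less compound is needed, a higher number that more compound is needed for the effect), gives 634 nM. Compound 2, `CCCS(=O)(=O)Nc1cccc2c1CCC2c1ncc[nH]1`, in this assay reaches only the limit > 10000 nM. Compound 3, `COc1cccc2c1CCC2c1ncc[nH]1`, in this assay likewise reaches only the limit > 10000 nM.

Compound 3 therefore stands at the limit of this assay, where it shares its place with one other of the three values (the limit of > 10000 nM in this assay, at which 2 of the 3 values shown sit), and its true number is not known. The next compound, compound 4, `c1ccc2c(c1)CCC2c1ncc[nH]1`, differs from it in one place: hydrogen in place of methoxy on an aromatic carbon. Among the measured compounds shown here, of the measured steps, the one toward compound 3 is read as an at least 15-fold higher number from compound 1 to compound 3 (1.19 log units; beyond the scatter), a large loss in this assay, while a step that the two limits leave unreadable from compound 2 to compound 3 cannot be sized because both ends sit at the limit. For the measured compounds named here, no measured step removes a group to leave bare hydrogen, so the new step rests on little. Since compound 3 itself is only a limit, compound 4 is expected to remain near that limit, with an estimated value of 15000 nM in this assay, between 5000 nM and 50000 nM, meaning a step that the limit leaves unreadable from compound 3 to compound 4 that is expected to stay within the scatter.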

Compound 4, half-maximal effective concentration: > 10000 nM
Compound 4 ended at the assay's limit; the forecaster's own chance of this, stated with the estimate: 75%; the middle value does not contradict the limit.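

In this assay compound 4 gives > 10000 nM, which is a limit and not a number. Hydrogen in place of 3-methyl-1H-pyrazol-4-yl gives an at least 15-fold higher number from compound 1 to compound 4 (1.19 log units; beyond the scatter), so having no group at all on this aromatic carbon matches the loss already seen with methoxy and (propylsulfonyl)amino. Among the compounds shown, only compound 1, with its 3-methyl-1H-pyrazol-4-yl, gives a readable number, while the others sit together: the limit of > 10000 nM in this assay, at which 3 of the 4 values shown sit.

From the compounds shown here alone, the steps among compound 2, compound 3 and compound 4 cannot be read, so how far apart these compounds truly lie stays unknown. Going by these compounds, it also remains open whether a phenyl ring or an amine on this aromatic carbon would give a readable number, as the 3-methyl-1H-pyrazol-4-yl does.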